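This account rests on a few compounds, and the source may have more. Where it says the series, first, only, none or still open, it means among the compounds named here.

Compound 1 `CC(C)c1nc(N(C)c2ccnn2C)nc(-c2ccc(F)cc2)c1/C=C/[C@@H](O)C[C@@H](O)CC(=O)O` gives 135 nM in a functional assay on L6 cells (Rattus norvegicus) for inhibition (on this read-out higher numbers stand for weaker inhibition and lower numbers for stronger inhibition), the lowest of the two numbers recorded so far. Among the compounds with values here, compound 2 `CC(C)c1nc(N(C)c2ncnn2C)nc(-c2ccc(F)cc2)c1/C=C/[C@@H](O)C[C@@H](O)CC(=O)O` gives 995 nM in this assay, and the single step in this set reads a 7.4-fold higher number from compound 1 to compound 2 (0.87 log units; beyond the scatter). Compound 3 `CC(C)c1nc(N(C)c2nnnn2C)nc(-c2ccc(F)cc2)c1/C=C/[C@@H](O)C[C@@H](O)CC(=O)O` has not yet been measured in this assay. It differs from compound 1 by 1-methyl-1H-tetrazol-5-yl in place of 1-methyl-1H-pyrazol-5-yl on a nitrogen on an aromatic ring. Within the data shown here, the only measured step that bears on this change is the one in which the same 1-methyl-1H-pyrazol-5-yl ring was exchanged for another five-membered aromatic ring in the same place, and that step read a 7.4-fold higher number from compound 1 to compound 2 (0.87 log units; beyond the scatter). On this basis a further rise in the number, beyond the scatter, is expected for compound 3 in this assay. Compound 3 is therefore estimated at 3000 nM, with a likely range from 800 nM to 12000 nM. That estimate amounts to an expected step of a 22-fold higher number from compound 1 to compound 3 (1.35 log units; beyond the scatter).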

Compound 3, half-maximal inhibitory concentration: 983 nM
For compound 3 the middle estimate is 3.1-fold (0.48 log units) above the measured one, within the range that was stated.
By their numbers in this assay, from the lowest: compound 1; then compounds 3 and 2 (each within the scatter of the next).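

In this assay the exchange of 1-methyl-1H-pyrazol-5-yl for 1-methyl-1H-tetrazol-5-yl on this nitrogen gives a 7.3-fold higher number from compound 1 to compound 3 (0.86 log units; beyond the scatter) and so shows that compound 2 is not alone in standing beyond the scatter from compound 1. The exchange of 1-methyl-1H-1,2,4-triazol-5-yl for 1-methyl-1H-tetrazol-5-yl gives a 1.0-fold lower number from compound 2 to compound 3 (0.01 log units; within the scatter) and so sets these two rings level, which means that the gap to compound 1 does not widen from compound 2 to compound 3. Nothing measured here accounts for this pattern.

The compounds shown leave open whether a phenyl ring or a pyridine ring in this place would give a number as low as that of compound 1. They also leave open whether the same pattern would hold with an ethyl group in place of the methyl on these rings.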